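Notes on a Chlorophenyl Shift in Three Measured Analogues

The source may report more compounds than this note shows. Statements on the series, on what has been measured and on what is new or still open speak of the compounds shown alone.

Measured so far in an assay on isolated protein for inhibition of DNA topoisomerase 1 (Homo sapiens), with a stated time of 30 min, tested at 100 uM; on this read-out lower numbers stand for a weaker effect and higher numbers for a stronger effect at the one concentration tested:
compound 1 `Oc1cccc(-c2cc(-c3cccnc3)nc(-c3cccc(Cl)c3)c2)c1`: 27.6%
compound 2 `Oc1cccc(-c2cc(-c3cccc(Cl)c3)nc(-c3ccccn3)c2)c1`: 0.4%
compound 3 `Oc1cccc(-c2cc(-c3ccsc3)nc(-c3cccc(Cl)c3)c2)c1`: 26.2%

Compound 3 stands second highest of the three numbers. Its nearest neighbour is compound 1, and the step of a number 1.4 percentage points lower from compound 1 to compound 3 (within the scatter) lies within the scatter. Its furthest is compound 2, with the step of a number 25.8 percentage points higher from compound 2 to compound 3 (beyond the scatter) beyond the scatter, matching the step of a number 27.2 percentage points lower from compound 1 to compound 2 (beyond the scatter) seen from the same pyridin-2-yl compound.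

Compound 4 `Oc1cccc(-c2cc(-c3ccsc3)nc(-c3ccccc3Cl)c2)c1` is the next analogue. Its difference from compound 3 is 2-chlorophenyl in place of 3-chlorophenyl on an aromatic carbon. Among the compounds with values here, all three measured steps alter the pyridinyl or thiophenyl group; none of them changes the chlorophenyl group, so no measured step bears directly on this change. Within the data shown here, with no direct precedent, the expectation for compound 4 is a step of a number 2.2 percentage points lower from compound 3 to compound 4 (within the scatter) that stays within the scatter of compound 3. Compound 4 is therefore estimated at 24% in this assay, with a range from 6% to 42%.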

Compound 4, a percentage reported as inhibition, at one concentration (the size of the read-out at that concentration, not a potency): 0%
Compound 4: the middle estimate sits 24 percentage points above what was measured; the measured number lies below the stated range.
By their numbers in this assay, from the lowest: compounds 4 and 2 (each within the scatter of the next); then compounds 3 and 1 (each within the scatter of the next).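

Within the data shown here, the chlorophenyl group, which no earlier step touched, proves sensitive to where its chlorine sits: in this assay, 2-chlorophenyl in place of 3-chlorophenyl gives a number 26.2 percentage points lower from compound 3 to compound 4 (beyond the scatter). The two groups have the same atoms and the same computed counts, so this read-out separates them by how those atoms are joined alone. The earlier steps tied changes in the number only to the pyridinyl or thiophenyl group, whereas this one shows that the group on the aromatic carbon next to the ring nitrogen matters too, although no measurement given here explains the drop.

Still open, from the compounds shown here alone, is whether the same shift lowers the number with pyridin-3-yl in place of thiophen-3-yl. Also open, going by these compounds, is whether unsubstituted phenyl, 3-methoxyphenyl or 3-aminophenyl at this position would stay with compound 3 or fall with compound 4.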